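Piperazine series: pyrimidin-2-yl replacing the methylsulfanylphenyl group

The source may hold more compounds than are shown below. What is called first, only, known or untested is meant among the compounds shown, and "the series" means these compounds.

Compound 2 `CSc1ccccc1N1CCN(Cc2nc3ccccc3[nH]2)CC1` carries a 2-(methylsulfanyl)phenyl group on the ring nitrogen; in an assay on HEK293 cells with D(4) dopamine receptor (Homo sapiens) as the target, read by FLIPR (a lower number here means that less compound is needed, a higher number that more compound is needed for the effect), compound 2 gives 86 nM. Compound 1 `Fc1cccnc1N1CCN(Cc2nc3ccccc3[nH]2)CC1` is the only comparator, and in this assay compound 1 gives 24 nM. Compound 2 therefore stands at the higher of the two numbers, with a 3.6-fold higher number from compound 1 to compound 2 (0.55 log units; beyond the scatter) separating the pair. That single step is also the only measured one at this position: it exchanged a six-membered aromatic ring holding a nitrogen atom for a six-membered ring of carbon only, and the number rose.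

Compound 3 `c1cnc(N2CCN(Cc3nc4ccccc4[nH]3)CC2)nc1` differs from compound 2 by pyrimidin-2-yl in place of 2-(methylsulfanyl)phenyl on an amine nitrogen in a ring. For the measured compounds named here, the change runs opposite to the measured step in that an all-carbon ring gives way to a ring with two hetero atoms, so a modest move downward, comparable in size to the one step available, is the expectation; a move beyond the scatter is not assured. Compound 3 is accordingly expected to give about 40 nM in this assay, within 12 nM to 150 nM, that is a 2.2-fold lower number from compound 2 to compound 3 (0.33 log units; beyond the scatter).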

Compound 3, half-maximal effective concentration: 44.8 nM
The estimate for compound 3 lay 1.1-fold (0.05 log units) below the measured number; the measured number falls inside the stated range.
By their numbers in this assay, from the lowest: compounds 1, 3 and 2 (each within the scatter of the next, the first and the last beyond it).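

In this assay, for the compounds shown here, pyrimidin-2-yl on the amine nitrogen in the ring lies within the scatter of both earlier groups (a 1.9-fold lower number from compound 2 to compound 3 (0.28 log units; within the scatter); a 1.9-fold higher number from compound 1 to compound 3 (0.27 log units; within the scatter)), whereas the one earlier step at this position lay beyond it (a 3.6-fold higher number from compound 1 to compound 2 (0.55 log units; beyond the scatter)). The exchange of a six-membered aromatic ring of carbon only for one with 2 hetero atoms therefore does not by itself give a step beyond the scatter, so the pair of compound 1 and compound 2 cannot be read as a simple split between rings with and without ring nitrogen, and compound 3 stays unresolved from either neighbour. Nothing in hand gives a measured property that would account for these numbers.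

The compounds shown all carry a six-membered aromatic ring at this position, so it remains open how a saturated group such as cyclohexyl, or an acetyl group, would read here. Also open, as far as these compounds go, is whether a pyridin-2-yl group without fluorine, or a carboxylic acid or an amine on the aromatic ring, would move the number beyond the scatter of this trio.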